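The source may report more compounds than this note shows. Statements on the series, on what has been measured and on what is new or still open speak of the compounds shown alone.

Compound 1 `C=CC(=O)Nc1cc(Nc2ncc(Cl)c(Nc3ccccc3S(=O)(=O)C(C)C)n2)c(OC)cc1N1CCN(S(C)(=O)=O)CC1` gives < 0.3 nM in a functional assay on NCI-H3122 cells (Homo sapiens) for inhibition, read by CellTiter-Glo, with a stated time of 72 h; a higher number here means a weaker inhibitor of growth, a lower number a stronger inhibitor of growth; this value is a limit of the assay, not a number.
Compound 2 `C=CC(=O)Nc1cc(Nc2ncc(Cl)c(Nc3ccccc3S(=O)(=O)C(C)C)n2)c(OC)cc1N1CCN(C(C)C)CC1` gives < 0.3 nM in this assay; this value too is a limit of the assay.

Among the compounds with values here, compound 2 therefore stands at the lower edge of what this assay can report, and so does the only other compound measured, as both sit at the limit of < 0.3 nM in this assay, at which 2 of the 2 values shown sit. Within the data shown here, the one step between measured compounds, a step that the two limits leave unreadable from compound 1 to compound 2, cannot be read, since neither end of it is a number. Compound 3 `C=CC(=O)Nc1cc(Nc2ncc(Cl)c(Nc3ccccc3S(=O)(=O)C(C)C)n2)c(OC)cc1N1CCN(C2CCCCC2)CC1` differs from compound 2 by cyclohexyl in place of isopropyl on an amine nitrogen in a ring. Whether such a change on the ring nitrogen matters cannot be taken from the measured step, which bears on the same ring nitrogen but has no readable size. The expectation for compound 3 is simply that it remains at or near the limit, estimated at 0.2 nM with a range from 0.05 nM to 1 nM. The step from compound 2 to compound 3 is expected to be a step that the limit leaves unreadable from compound 2 to compound 3, most likely reported again as a limit rather than a number.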

Compound 3, concentration for 50% growth inhibition: < 0.3 nM
Compound 3: a limit, no number; the forecaster's own chance of this, stated with the estimate: 70%; the middle value is on the limit's open side.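

Compound 3, like compound 1 and compound 2, returns only a limit of the assay and not a number, so no step among these three compounds can be read: the limit of < 0.3 nM in this assay, at which 3 of the 3 values shown sit. The compounds shown leave open whether methylsulfonyl, isopropyl and cyclohexyl on the ring nitrogen differ at all in this assay.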